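This account rests on a few compounds, and the source may have more. Where it says the series, first, only, none or still open, it means among the compounds named here.

In a functional assay on HeLa cells (Homo sapiens) for antiproliferative activity, read by spectrophotometry, with a stated time of 2 days (a lower number here means a stronger inhibitor of growth, a higher number a weaker inhibitor of growth), two compounds with the same core have been measured so far. Compound 1 `Cc1ccc(Nc2ncc(C(F)(F)F)c(N3Cc4cccc(N(C)S(C)(=O)=O)c4C3)n2)cc1C` gives only a limit, > 30000 nM, and not an exact number. For the measured compounds named here, compound 2 `Cc1ccc(Nc2ncc(C(F)(F)F)c(N3Cc4cccc(N(C)S(C)(=O)=O)c4C3)n2)c(C)c1` gives 10600 nM, the only exact number available, so it is the reference point for what follows.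

Compound 3 `CN(c1cccc2c1CN(c1nc(Nc3cc(Cl)cc(C(F)(F)F)c3)ncc1C(F)(F)F)C2)S(C)(=O)=O` keeps the shared core and changes one group: 3-chloro-5-(trifluoromethyl)phenyl replaces 2,4-dimethylphenyl on a nitrogen on an aromatic ring, (3-chloro-5-(trifluoromethyl)phenyl in place of 2,4-dimethylphenyl on a nitrogen on an aromatic ring).

Going by the values given here, one measured step bears on this change, because it concerns the same place: an at least 2.8-fold lower number from compound 1 to compound 2 (0.45 log units; beyond the scatter). That step shows that growth inhibition can respond to a change at this place, even when only the dimethylphenyl pattern differs. However, it involves neither chlorine nor trifluoromethyl on this ring, so it gives no direction for the new group. The best single expectation is therefore no step beyond the scatter, with real uncertainty on both sides. The expected change is a 1.3-fold lower number from compound 2 to compound 3 (0.12 log units; within the scatter). For compound 3, the estimated value is 8000 nM, with an expected range from 2000 nM to 30000 nM.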

Compound 3, concentration for 50% growth inhibition: 4300 nM
The estimate for compound 3 lay 1.9-fold (0.27 log units) above the measured number; the range from low to high includes it.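

In this assay, putting 3-chloro-5-(trifluoromethyl)phenyl in place of 2,4-dimethylphenyl gives a 2.5-fold lower number from compound 2 to compound 3 (0.39 log units; beyond the scatter), so this position accepts a ring that carries chlorine and trifluoromethyl and no methyl group, and the number still improves. Measured against 3,4-dimethylphenyl, the same ring gives an at least 6.9-fold lower number from compound 1 to compound 3 (0.84 log units; beyond the scatter), which makes compound 3 the strongest inhibitor of growth of the three, though this step can only be read as a minimum size. Compound 1 is known only through a limit of the assay: the limit of > 30000 nM in this assay, at which 1 of the 3 values shown sits.

The compounds shown leave open whether chlorine, trifluoromethyl or the two together account for the gain, since both groups enter in a single change and neither is seen alone on this ring. They also leave open how growth inhibition would respond to other groups on this ring, such as a nitrile, a methoxy group, an amine or a carboxylic acid, or to a ring containing nitrogen in place of the phenyl.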